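The source may hold more compounds than are shown below. What is called first, only, known or untested is meant among the compounds shown, and "the series" means these compounds.

Going by the values given here, compound 2 `Cc1cccc(-c2nnn(CC(=O)Nc3cc(C)nn3C3CCCCC3)n2)c1` gives 129 nM in an assay on HEK293 cells for activation of Kir3.1/Kir3.2 (Homo sapiens), read by thallium flux (a higher number here means that more compound is needed for the effect, a lower number that less compound is needed), the lowest of the two numbers so far; compound 1 `Cc1cc(NC(=O)Cn2nnc(-c3ccccn3)n2)n(C2CCCCC2)n1` gives 14600 nM. Among the compounds with values here, the only step, a 110-fold lower number from compound 1 to compound 2 (2.05 log units; beyond the scatter), swapped the whole aryl group on the shared core. Compound 3 `COc1ccc(-c2nnn(CC(=O)Nc3cc(C)nn3C3CCCCC3)n2)cc1` carries 4-methoxyphenyl in place of 3-methylphenyl on an aromatic carbon. No measured step bears on a change within the phenyl ring itself, so the size and direction are uncertain; a modest rise in the number is expected for compound 3, within the aryl-sensitive range shown. The estimated value for compound 3 in this assay is 350 nM, between 70 nM and 2000 nM, an expected step of a 2.7-fold higher number from compound 2 to compound 3 (0.43 log units; beyond the scatter).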

Compound 3, half-maximal effective concentration: 175 nM
Compound 3: the middle estimate sits 2.0-fold (0.30 log units) above what was measured, within the range that was stated.
By their numbers in this assay, from the lowest: compounds 2 and 3 (each within the scatter of the next); then compound 1.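

In this assay the swap shows a 1.4-fold higher number from compound 2 to compound 3 (0.13 log units; within the scatter) and so does not separate 4-methoxyphenyl from 3-methylphenyl on this aromatic carbon. Against pyridin-2-yl, the same position shows an 83-fold lower number from compound 1 to compound 3 (1.92 log units; beyond the scatter) for 4-methoxyphenyl, so the large gap seen with 3-methylphenyl is not confined to that one group. No evidence on hand bears on the reason for either step. Open, from the compounds shown here alone, is whether the substituent on the phenyl ring matters at all: unsubstituted phenyl or 4-chlorophenyl would test this, and cyclohexyl at this carbon would test whether an aromatic ring is needed.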